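Trifluoromethyl to methoxy on the aromatic ring

This account rests on a few compounds, and the source may have more. Where it says the series, first, only, none or still open, it means among the compounds named here.

In an ADME assay on HEK293 cells (Homo sapiens) for cytotoxicity, read by MTT assay, with a stated time of 24 h (a lower number here means a stronger inhibitor, a higher number a weaker inhibitor), compound 1 `Cc1ccc(CNc2nc3ccc([N+](=O)[O-])cc3nc2NCCCN(C)C)cc1` gives 15.8 ug/mL and compound 2 `CN(C)CCCNc1nc2cc([N+](=O)[O-])ccc2nc1NCc1ccccc1C(F)(F)F` gives 24.7 ug/mL. Among the measured compounds shown here, compound 2 therefore stands within the scatter of the only other measured compound. Compound 3 `COc1ccccc1CNc1nc2ccc([N+](=O)[O-])cc2nc1NCCCN(C)C` keeps the shared core and carries methoxy in place of trifluoromethyl on an aromatic carbon, turning 2-(trifluoromethyl)phenyl into 2-methoxyphenyl: methoxy in place of trifluoromethyl on an aromatic carbon. For the measured compounds named here, one measured step bears on this change, a 1.6-fold higher number from compound 1 to compound 2 (0.19 log units; within the scatter), where the aromatic ring's substituent also changed. Going by the values given here, no measured compound carries methoxy, so this single step is only indirect evidence. With that step as the guide, no change beyond the scatter is expected in this assay. The estimated move is a 1.2-fold lower number from compound 2 to compound 3 (0.09 log units; within the scatter). Compound 3 is expected to give about 20 ug/mL, with an estimated range of 9 ug/mL to 42 ug/mL.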

Compound 3, half-maximal inhibitory concentration: 36.1 ug/mL
Compound 3: middle estimate off by 1.8-fold (0.26 log units), on the low side; low and high end bracket the measured number.
By their numbers in this assay, from the lowest: compounds 1, 2 and 3 (each within the scatter of the next, the first and the last beyond it).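

In this assay, methoxy in place of trifluoromethyl on an aromatic carbon, ortho to a large group, gives a 1.5-fold higher number from compound 2 to compound 3 (0.16 log units; within the scatter), so this direct exchange does not separate the two groups. Among the compounds shown here, compound 3 does, however, separate from compound 1, with 2-methoxyphenyl in place of 4-methylphenyl giving a 2.3-fold higher number from compound 1 to compound 3 (0.36 log units; beyond the scatter), the first step in this short series to pass beyond the scatter, though only a modest one, and compound 2 stays within the scatter of both. For the compounds shown here, nothing available here explains why the one step passes the scatter and the other does not.

Three compounds do not show whether the same aromatic carbon tolerates other groups. An amine, a carboxylic acid or a longer chain such as ethoxy might stay close to compound 2 or move clearly away from it, and 4-methoxyphenyl remains an open comparison with 4-methylphenyl.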